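The compounds below may be only part of what the source reports. "The series", "measured", "known", "first", "only" and "open" are said of these compounds alone.

In a functional assay on NCI-H460 cells (Homo sapiens) for cytotoxicity, read by MTT assay, with a stated time of 72 h (on this read-out higher numbers stand for weaker inhibition and lower numbers for stronger inhibition), three compounds have been measured. Compound 1 `O=Cc1cn(Cc2ccc(Cl)cc2)c2ccccc12` gives 850 nM, compound 2 `CC1CCN(Cc2ccc3nc(NC(=O)N/N=C/c4cn(Cc5ccc(Cl)cc5Cl)c5ccccc45)sc3c2)CC1` gives 1660 nM, and compound 3 `CCN(CC)Cc1ccc2nc(NC(=O)N/N=C/c3c[nH]c4ccccc34)sc2c1` gives 3140 nM. Among these, compound 3 shows the highest number; its gap to compound 2 lies within the scatter, while its gap to compound 1 lies beyond it. Compound 4 `CCN(CC)Cc1ccc2nc(NC(=O)N/N=C/c3cn(Cc4ccc(C)cc4)c4ccccc34)sc2c1` has not yet been measured. It differs from compound 3 in one place: 4-methylbenzyl in place of hydrogen on an aromatic nitrogen. Within the data shown here, no measured pair isolates this change, so the expected step is uncertain, and a modest decrease in the number, perhaps still within the scatter, is expected, namely a 2.0-fold lower number from compound 3 to compound 4 (0.29 log units; within the scatter). Compound 4 is expected to give about 1600 nM, within 600 nM to 4500 nM, because compound 2 gives 1660 nM.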

Compound 4, half-maximal inhibitory concentration: 320 nM
Beside the measured number, compound 4's estimate is 5.0-fold (0.70 log units) above it, outside the stated range (below it).
By their numbers in this assay, from the lowest: compound 4; then compounds 1, 2 and 3 (each within the scatter of the next, the first and the last beyond it).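

In this assay, among these compounds, 4-methylbenzyl in place of hydrogen on the aromatic nitrogen brings a 9.8-fold lower number from compound 3 to compound 4 (0.99 log units; beyond the scatter) and gives the first reading of a single change at this position. This nitrogen of the five-membered aromatic ring therefore accepts a large group, and here that group goes with stronger inhibition. Nothing given here accounts for the step.

On these data alone, whether the methyl, the benzyl ring or mere substitution matters remains open. How plain benzyl, an ethyl chain or an aminoethyl group would compare on this nitrogen is also unknown.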